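This account rests on a few compounds, and the source may have more. Where it says the series, first, only, none or still open, it means among the compounds named here.

Measured: compound 1 `CCn1c(C(=O)NCCCN(C)C)ccc1C(CC)(CC)c1ccc(OCCC(O)(CC)CC)c(C)c1`, which in an assay on cells for agonist activity at vitamin D3 receptor (Homo sapiens), with a stated time of 96 h (a higher number here means that more compound is needed for the effect, a lower number that less compound is needed), gives 5 nM; compound 2 `CCn1c(C(=O)Nc2cccc(C(F)(F)F)c2)ccc1C(CC)(CC)c1ccc(OCCC(O)(CC)CC)c(C)c1`, which in this assay gives 5900 nM.

Compound 2 stands at the highest of the two numbers, separated from compound 1 by the step of a 1200-fold higher number from compound 1 to compound 2 (3.07 log units; beyond the scatter). Compound 3 `CCOc1ccc(NC(=O)c2ccc(C(CC)(CC)c3ccc(OCCC(O)(CC)CC)c(C)c3)n2CC)cc1` differs from compound 2 by 4-ethoxyphenyl in place of 3-(trifluoromethyl)phenyl on an amide-type nitrogen. Going by the values given here, the one measured step swapped an alkylamine chain for an aryl group on the amide nitrogen; the present change keeps an aryl group there, so no step beyond the scatter is expected in this assay. Compound 3 is estimated at 4000 nM (range 1000 nM to 15000 nM), an expected step of a 1.5-fold lower number from compound 2 to compound 3 (0.17 log units; within the scatter).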

Compound 3, half-maximal effective concentration: 1630 nM
Compound 3: the middle estimate sits 2.5-fold (0.39 log units) above what was measured; low and high end bracket the measured number.
By their numbers in this assay, from the lowest: compound 1; then compound 3; then compound 2.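

In this assay the aryl group on the amide-type nitrogen matters: 4-ethoxyphenyl in place of 3-(trifluoromethyl)phenyl gives a change beyond the scatter (a 3.6-fold lower number from compound 2 to compound 3 (0.56 log units; beyond the scatter)). That change remains small beside the gap to the alkylamine chain (a 330-fold higher number from compound 1 to compound 3 (2.51 log units; beyond the scatter)), so neither aryl amide comes near compound 1. Nothing available bears on the reason for either step. The two aryl names differ in both substituent and number, so these cannot be separated here. As far as these compounds go, whether a piperidine or a carboxylic acid on that chain would keep the number of compound 1 stays open.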